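This account rests on a few compounds, and the source may have more. Where it says the series, first, only, none or still open, it means among the compounds named here.

Measured so far:
compound 1 `COc1ccc(/C(=N\NC(=O)Nc2nnc(COc3ccc4ccccc4c3)o2)c2ccccc2)cc1` — 300 mg/kg
compound 2 `C/C(=N/NC(=O)Nc1nnc(COc2ccc3ccccc3c2)o1)c1ccc(N)cc1` — 300 mg/kg
compound 3 `O=C(NN=C(c1ccccc1)c1ccccc1)Nc1nnc(COc2ccc3ccccc3c2)o1` — 300 mg/kg

All three share the same core and were tested in a functional assay on the whole organism (strain Swiss albino) with Mus musculus as the target, in the maximal electroshock model, with a stated time of 4 h; on this read-out lower numbers stand for an effect already at smaller amounts and higher numbers for an effect only at larger amounts of compound. Compound 1 gives 300 mg/kg, compound 2 gives 300 mg/kg and compound 3 gives 300 mg/kg, so the three values sit level with each other within the scatter. Going by the values given here, the one step between compounds that differ in a single place, no change at the digits printed from compound 1 to compound 3 (within the scatter), shows no change within the scatter for hydrogen in place of methoxy on an aromatic carbon. Compound 2 stands level with compound 1 and compound 3 at the digits shown, nearest to compound 1 and furthest from compound 3, both without change within the scatter.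

The next compound, compound 4 `C/C(=N/NC(=O)Nc1nnc(COc2ccc3ccccc3c2)o1)c1ccc(O)cc1`, has not been measured in this assay. It differs from compound 2 by hydroxy in place of amino on an aromatic carbon, that is, 4-aminophenyl to 4-hydroxyphenyl. Among the compounds with values here, no measured step covers this exact change; the only step at hand concerns a substituent on an aromatic carbon and was flat. With the whole set sitting at one level, no step beyond the scatter is expected in this assay, so no change at the digits printed from compound 2 to compound 4 (within the scatter) is estimated as essentially flat. Compound 4 is therefore expected to give about 300 mg/kg, with a range of 100 mg/kg to 600 mg/kg.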

Compound 4, minimum effective dose: 300 mg/kg
Compound 4: the middle estimate sits on the measured number at the digits printed; measured number inside the range.
By their numbers in this assay, from the lowest: compounds 1, 2, 3 and 4 (each within the scatter of the next).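

In this assay, going by these compounds alone, hydroxy in place of amino on an aromatic carbon, para to a large group, gives no change at the digits printed from compound 2 to compound 4 (within the scatter), the first reading for the change from 4-aminophenyl to 4-hydroxyphenyl. This exchange swaps nitrogen for oxygen while the counted hydrogen-bond donor, hydrogen-bond acceptor and net charge stay the same, so the series now has a second flat substituent step on an aromatic carbon, alongside the earlier no change at the digits printed from compound 1 to compound 3 (within the scatter), which replaced methoxy with hydrogen. No supporting measurement bears on why this exchange leaves the read-out level, so the result stands only as an observation for this pair.

With all four compounds level, the series gives no indication of whether any substituent at this position can move the minimum effective dose beyond the scatter, and a carboxylic acid, a dimethylamino group or a longer chain such as butoxy in place of hydroxy would test that directly. The compounds shown also leave open whether a change within the shared core would separate the values in a way that substituents on this aromatic ring have not.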